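Imidazolidinone to Aminothiazole: Expected Metabolic Stability

A few compounds are considered here, and "the series" means these few. Any claim that something is new, unique, unknown or untested is made for them only; others in the source may bear on it.

Compound 1 `CCn1ncc2c(F)cc(-c3ccc(C(CC)(CC)c4nnc(C)[nH]4)c(=O)[nH]3)cc21`: > 3 h
Compound 2 `CCn1ncc2c(F)cc(-c3ccc(C(CC)(CC)c4ncn(C)n4)c(=O)[nH]3)cc21`: > 3 h
Compound 3 `CC(C)C(c1ccc(-c2ccc3cccc(F)c3c2)[nH]c1=O)N1CCNC1=O`: 0.283 h

In an ADME assay on microsomes from liver (Rattus norvegicus) for metabolic stability (a lower number here means that the compound disappears faster, a higher number that the compound lasts longer), compound 1 gives > 3 h, which is a limit of the assay and not a number. Compound 2 gives > 3 h in this assay, also a limit. The step that the two limits leave unreadable from compound 1 to compound 2 is therefore unreadable. Within the data shown here, compound 3 gives 0.283 h in this assay, the only number among the three values. The other two sit at the limit of > 3 h in this assay, at which 2 of the 3 values shown sit.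

Compound 4 `CC(C)C(c1cnc(N)s1)c1ccc(-c2ccc3cccc(F)c3c2)[nH]c1=O` differs from compound 3 in one place: 2-amino-1,3-thiazol-5-yl in place of 2-oxoimidazolidin-1-yl on a saturated chain carbon bound to an aromatic carbon and a saturated chain carbon. Among the measured compounds shown here, no measured step involves this change, and the only measured step cannot be read, so nothing points to a direction or size beyond the scatter. Compound 4 is estimated at 0.3 h, between 0.1 h and 0.9 h. That estimate means an expected step of a 1.1-fold higher number from compound 3 to compound 4 (0.03 log units; within the scatter).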

Compound 4, half-life: 0.0983 h
The estimate for compound 4 lay 3.1-fold (0.48 log units) above the measured number, outside the stated range (below it).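

In this assay, this place on the saturated chain carbon now gives a readable step: 2-amino-1,3-thiazol-5-yl in place of 2-oxoimidazolidin-1-yl gives a 2.9-fold lower number from compound 3 to compound 4 (0.46 log units; beyond the scatter). Both groups are five-membered rings with 6 heavy atoms, yet the change goes beyond the scatter, so the number responds to which ring sits here. Nothing measured here explains the drop.

Among these compounds, the one step between compound 1 and compound 2 still cannot be read, as both values are limits of the assay. Also open, as far as these compounds go, is how a carboxylic acid on this carbon would compare, and whether the amino group on the thiazole plays any part in the step.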